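Cytotoxicity notes: sulfonamide piperidinyl-piperidines, removing the isopropyl

The compounds below may be only part of what the source reports. "The series", "measured", "known", "first", "only" and "open" are said of these compounds alone.

Two members of the series have been run in an ADME assay on HCT-116 cells (Homo sapiens) for cytotoxicity, read by CellTiter-Glo, with a stated time of 72 h (a higher number here means a weaker inhibitor, a lower number a stronger inhibitor), so far, and neither gave a number. Compound 1 `Cc1ccc(S(=O)(=O)N2CCC(N3CCC(C)CC3)CC2)cc1C` carries a methyl on the far saturated ring. In this assay compound 1 sits at the limit of > 5000 nM. Compound 2 `Cc1cc(C)c(S(=O)(=O)N2CCC(N3CCC(C(C)C)CC3)CC2)c(C)c1` carries an isopropyl at the same place on the far ring. In this assay compound 2 likewise sits at the limit of > 5000 nM. Since both values are limits, compound 2 cannot be placed relative to compound 1; the two results only show that neither was resolved, as summarised by the limit of > 5000 nM in this assay, at which 2 of the 2 values shown sit.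

Compound 3 `Cc1cc(C)c(S(=O)(=O)N2CCC(N3CCCCC3)CC2)c(C)c1` is the next point: relative to compound 2 the change is hydrogen in place of isopropyl on a saturated ring carbon.

Expectation for this step. With no resolved number on either side, the sensible guess is that compound 3 stays where the series has been so far. The step that the limit leaves unreadable from compound 2 to compound 3 is expected to be none beyond the scatter. Compound 3 is therefore estimated at 10000 nM, with a range of 4000 nM to 30000 nM, and a further limit rather than a number is the most likely outcome.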

Compound 3, half-maximal inhibitory concentration: > 5000 nM
Compound 3: only a limit was reported; the forecaster's own chance of this, stated with the estimate: 85%; the middle value is on the limit's open side.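

Compound 2 and compound 3 each returned only a limit, so the step between them cannot be read, and swapping the isopropyl for hydrogen yields no size of change. What stays open is where any of the three compounds actually lies, since the series so far rests on a single shared limit: the limit of > 5000 nM in this assay, at which 3 of the 3 values shown sit.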